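A few compounds are considered here, and "the series" means these few. Any claim that something is new, unique, unknown or untested is made for them only; others in the source may bear on it.

The series rests on a shared glycosylated core. Compound 1 `CCOC(=O)[C@@H](NC(=O)C(CO)(CO)NC(=O)CCCC(=O)O)[C@@H](C)O[C@@H]1O[C@@H](C)[C@@H](O)C(O)C1O` gives 900000 nM in an assay on isolated protein for inhibition of E-selectin (Homo sapiens) (on this read-out lower numbers stand for stronger inhibition and higher numbers for weaker inhibition), compound 2 `CCOC(=O)[C@@H](NC(=O)[C@H]1C[C@H](O)CN1C(=O)CCCC(=O)O)[C@@H](C)O[C@@H]1O[C@@H](C)[C@@H](O)C(O)C1O` gives 100000 nM, and compound 3 `CCOC(=O)[C@@H](NC(=O)[C@@H]1[C@@H](O)[C@@H](O)CN1C(=O)CCCC(=O)O)[C@@H](C)O[C@@H]1O[C@@H](C)[C@@H](O)C(O)C1O` gives 50000 nM. Compound 2 thus sits second highest of the three numbers: its gap to compound 3 lies within the usual scatter, while compound 1 stands beyond it. Compound 4 `CCOC(=O)[C@@H](NC(=O)[C@@H]1C[C@H](O)CN1C(=O)CCCC(=O)O)[C@@H](C)O[C@@H]1O[C@@H](C)[C@@H](O)C(O)C1O` remains unmeasured; it differs from compound 2 only in that (the two compounds have the same atoms and bonds; at least one stereo element is drawn with a configuration in one of them and without one in the other: 1 of 9 stereo elements differ; a stereocentre at a saturated ring carbon is drawn R in compound 2 and S in compound 4). For the measured compounds named here, no comparable stereochemical step has been measured, so the expected step from compound 2 to compound 4 is estimated as a 1.5-fold higher number from compound 2 to compound 4 (0.18 log units; within the scatter), a modest weakening at most and possibly none beyond the scatter. Compound 4 is accordingly expected to give about 150000 nM, with a likely range from 50000 nM to 500000 nM.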

Compound 4, half-maximal inhibitory concentration: 1000000 nM
For compound 4 the middle estimate is 6.7-fold (0.82 log units) below the measured one; measured number outside the range, above it.
By their numbers in this assay, from the lowest: compounds 3 and 2 (each within the scatter of the next); then compounds 1 and 4 (each within the scatter of the next).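

In this assay, changing only the configuration at this saturated ring carbon gives a 10-fold higher number from compound 2 to compound 4 (1.00 log units; beyond the scatter). For the compounds shown here, with atoms and bonds unchanged, this single stereocentre is thus enough to shift the read-out beyond the scatter, something the earlier compounds, which offered no pair differing in one place, could not show. One caution attaches to this reading: the fact that one of compounds 2 and 4 is drawn with a defined configuration and the other without, at the place where they differ

Going by these compounds, what remains open is whether the same stereochemical dependence would hold with an amine or a methoxy group in place of the ring hydroxyl. The compounds shown also leave open whether it would persist with a longer chain in place of the acid-bearing chain.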